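A few compounds are considered here, and "the series" means these few. Any claim that something is new, unique, unknown or untested is made for them only; others in the source may bear on it.

Compound 1, `C=CC1=C(C(=O)NC(C)(C)C)C(c2ccc(OC)cc2)OC1` — in a functional assay on QGY7701 cells (Homo sapiens) for cytotoxicity, read by MTT assay, with a stated time of 24 h (on this read-out lower numbers stand for stronger inhibition and higher numbers for weaker inhibition), compound 1 gives > 100000 nM, which is a limit of the assay rather than a number.
Compound 2, `C=CC1=C(C(=O)Nc2ccccc2)C(c2ccc(F)cc2)OC1` — in this assay compound 2 gives 46700 nM.
Compound 3, `C=CC1=C(C(=O)NCC(C)C)C(c2ccc(OC)cc2)OC1` — in this assay compound 3 gives > 100000 nM, again a limit and not a number.

Compound 3 thus stands at the limit of > 100000 nM in this assay, at which 2 of the 3 values shown sit, where compound 1 also sits, so the step that the two limits leave unreadable from compound 1 to compound 3 has no readable size. Compound 4, `C=CC1=C(C(=O)Nc2ccccc2)C(c2ccc(OC)cc2)OC1`, differs from compound 3 by phenyl in place of isobutyl on an amide-type nitrogen. Among the measured compounds shown here, no measured step covers this exact change; the one measured step, from compound 1 to compound 3, compares two limits and tells nothing about size. Compound 2 carries the same phenyl on its amide nitrogen, differs elsewhere, and in this assay gives a real number rather than a limit, 46700 nM. On that basis a step toward stronger inhibition is expected, an at least 1.6-fold lower number from compound 3 to compound 4 (0.22 log units; that floor lies within the scatter), though its size remains uncertain. Compound 4 is estimated at 60000 nM, with a range from 20000 nM to 150000 nM.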

Compound 4, half-maximal inhibitory concentration: > 100000 nM
Compound 4 ended at the assay's limit; the forecaster's own chance of this, stated with the estimate: 40%; middle value at least 1.6-fold (0.22 log units) from the limit.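

Phenyl on the amide nitrogen does not on its own bring a measurable number in this assay: compound 4 carries it and still gives > 100000 nM, which is a limit and not a number. Methoxy in place of fluoro on an aromatic carbon gives an at least 2.1-fold higher number from compound 2 to compound 4 (0.33 log units; beyond the scatter), the only step of readable size here, so the one real value, that of compound 2, goes with the fluoro as well as the phenyl. The steps from compound 1 and from compound 3 to compound 4 run between limits and cannot be read, and most of the set gives no sizes: the limit of > 100000 nM in this assay, at which 3 of the 4 values shown sit.

As far as these compounds go, whether phenyl helps at all while methoxy is present stays open. So does whether fluoro would give a number with tert-butyl or isobutyl on the amide nitrogen, and what chlorine or an amine would do on that aromatic carbon.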